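Aryl carbonyl replaced by dimethylpyrrole on the shared core

A few compounds are considered here, and "the series" means these few. Any claim that something is new, unique, unknown or untested is made for them only; others in the source may bear on it.

Compound 1 `CC1(C)C=C(n2ccccc2=O)c2cc(C(=O)c3ccccc3)ccc2O1` carries a phenyl group on a carbonyl carbon of the shared core, and in a functional assay (trachea) with Rattus norvegicus as the target (a lower number here means a less potent compound, a higher number a more potent compound, by a factor of ten per unit of this negative logarithm), compound 1 gives 6.21. Compound 2 `CC1(C)C=C(n2ccccc2=O)c2cc(C(=O)c3cccs3)ccc2O1` has thiophen-2-yl in place of phenyl on that carbonyl carbon; in this assay compound 2 gives 5.84, the step being a number 0.37 log units lower from compound 1 to compound 2 (beyond the scatter). Compound 3 `CC1(C)C=C(n2ccccc2=O)c2cc(C(=O)c3ccccc3F)ccc2O1` has fluoro in place of hydrogen on an aromatic carbon; in this assay compound 3 gives 6.34. Its steps are a number 0.13 log units higher from compound 1 to compound 3 (within the scatter) and a number 0.50 log units higher from compound 2 to compound 3 (beyond the scatter), so compound 3 holds the highest of the three numbers, though it cannot be separated from compound 1.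

Compound 4 `Cc1ccc(C)n1-c1ccc2c(c1)C(n1ccccc1=O)=CC(C)(C)O2` is the next step: 2,5-dimethyl-1H-pyrrol-1-yl in place of (2-fluorophenyl)carbonyl on an aromatic carbon. For the measured compounds named here, no measured step covers removal of the carbonyl, since compounds 1, 2 and 3 all keep an aromatic ring on a carbonyl carbon at this position. Going by the values given here, the only related information is the modest fall on exchanging phenyl for a five-membered heteroaryl ring, a number 0.37 log units lower from compound 1 to compound 2 (beyond the scatter), and the three measured numbers span only a narrow band. For compound 4 the expected step is a number 0.54 log units lower from compound 3 to compound 4 (beyond the scatter), downward beyond the scatter but with wide uncertainty. Compound 4 is therefore estimated at 5.8, within 5.2 to 6.4.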

Compound 4, logarithm of the reciprocal of the active concentration, log(1/C): 6.78
Beside the measured number, compound 4's estimate is 0.98 log units below it, and the stated range ends below it.
By their numbers in this assay, from the lowest: compound 2; then compounds 1 and 3 (each within the scatter of the next); then compound 4.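

In this assay the carbonyl is not needed at this aromatic carbon: 2,5-dimethyl-1H-pyrrol-1-yl, with its ring joined through nitrogen, gives a higher number than each aryl carbonyl shown (a number 0.44 log units higher from compound 3 to compound 4 (beyond the scatter); a number 0.57 log units higher from compound 1 to compound 4 (beyond the scatter); a number 0.94 log units higher from compound 2 to compound 4 (beyond the scatter)). All three steps lie beyond the scatter, so compound 4 is the most potent of the four, and this position accepts more than the narrow band of aryl carbonyl groups had shown. No evidence to hand accounts for the rise.

The change swaps the carbonyl and the aromatic ring together, so the compounds shown do not separate the loss of the carbonyl from the arrival of the pyrrole, nor show what the two methyl groups contribute. Also open, going by these compounds, is how the number would respond to an unsubstituted pyrrol-1-yl, a phenyl joined directly to this carbon, or an amine or a carboxylic acid at the same place.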